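The source may hold more compounds than are shown below. What is called first, only, known or untested is meant among the compounds shown, and "the series" means these compounds.

Compound 1 `CC(C)(C)c1ccc(CNCCCNS(=O)(=O)c2cc(C(F)(F)F)cc(C(F)(F)F)c2)cc1` belongs to a small set of three measured compounds built on a shared core, with a substituted benzyl group on the amine nitrogen. In a functional assay on ASPC1 cells (Homo sapiens) for inhibition, read by MTT assay, with a stated time of 72 h (on this read-out higher numbers stand for weaker inhibition of growth and lower numbers for stronger inhibition of growth), compound 1 gives 2700 nM, the lowest of the three numbers, although compound 3 is within the usual scatter of it. Compound 3 `O=S(=O)(NCCCNCc1ccc(Br)cc1)c1cc(C(F)(F)F)cc(C(F)(F)F)c1` gives 2800 nM in this assay, and a 1.0-fold higher number from compound 1 to compound 3 (0.02 log units; within the scatter). Compound 2 `O=S(=O)(NCCCNCc1ccc(Cl)c(C(F)(F)F)c1)c1cc(C(F)(F)F)cc(C(F)(F)F)c1` gives 9600 nM in this assay, and a 3.6-fold higher number from compound 1 to compound 2 (0.55 log units; beyond the scatter).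

Compound 4 `O=S(=O)(NCCCNCc1ccc(Cl)cc1)c1cc(C(F)(F)F)cc(C(F)(F)F)c1` has not yet been measured. It differs from compound 1 in one place: chloro in place of tert-butyl on an aromatic carbon. The step from compound 1 to compound 3, where another halogen took the place of tert-butyl at the same aromatic carbon, is the closest guide, and it stayed within the scatter. The step from compound 1 to compound 2 also brought in chloro, but together with a trifluoromethyl, so it is a weaker guide. The expected step is therefore a 1.1-fold higher number from compound 1 to compound 4 (0.05 log units; within the scatter), no larger than the scatter. Compound 4 is estimated at 3000 nM, with a range from 1500 nM to 6500 nM.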

Compound 4, concentration for 50% growth inhibition: 3000 nM
The estimate for compound 4 equals the measured number at the digits printed; the measured number falls inside the stated range.
By their numbers in this assay, from the lowest: compounds 1, 3 and 4 (each within the scatter of the next); then compound 2.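

Replacing tert-butyl with chloro takes this aromatic carbon's substituent from 4 heavy atoms to 1, yet a 1.1-fold higher number from compound 1 to compound 4 (0.05 log units; within the scatter) in this assay, and a 1.1-fold higher number from compound 3 to compound 4 (0.03 log units; within the scatter), so tert-butyl, bromo and chloro cannot be told apart at this place. Compound 4 also turns the comparison with compound 2 into a single change, hydrogen in place of trifluoromethyl with the chloro kept, and this gives a 3.2-fold lower number from compound 2 to compound 4 (0.51 log units; beyond the scatter), which makes compound 2 the only one of the four that stands apart. The measurements shown offer no explanation for either result.

On these data alone, it remains open whether a very different group at this place, such as methoxy, an amine or a carboxylic acid, would move the number beyond the scatter. The effect of a longer chain in the shared core is also unknown.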